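Working notes: trifluoromethyl in place of chloro

A few compounds are considered here, and "the series" means these few. Any claim that something is new, unique, unknown or untested is made for them only; others in the source may bear on it.

- compound 1 `O=C(CC(c1ccccc1)c1ccccc1)N1CCN(C(c2ccccc2)c2cccc(Cl)c2)CC1` gives 6 h
- compound 2 `O=C(NC(c1ccccc1)c1ccccc1)N1CCN(C(c2ccccc2)c2ccccc2)CC1` gives 6 h

In an in vivo ADME assay on the whole organism (strain Sprague-Dawley) for pharmacokinetics, with Rattus norvegicus as the target, at a dose of 10 mg/kg by the oral route (on this read-out higher numbers stand for a longer-lived compound and lower numbers for a shorter-lived compound), compound 1 gives 6 h and stands level with compound 2, within the usual scatter. The next compound to be read is compound 3 `O=C(CC(c1ccccc1)c1ccccc1)N1CCN(C(c2ccccc2)c2cccc(C(F)(F)F)c2)CC1`, which departs from compound 1 at one place (trifluoromethyl in place of chloro on an aromatic carbon): trifluoromethyl in place of chloro on an aromatic carbon, meta to a large group, so 3-chlorophenyl becomes 3-(trifluoromethyl)phenyl. Within the data shown here, no measured pair shows a step of this kind, so the data offer no size for it. No step beyond the scatter is therefore expected in this assay, in either direction, and compound 1 at 6 h serves as the anchor. The expected change is small, with no change at the digits printed from compound 1 to compound 3 (within the scatter) as the estimate. For compound 3 the estimated value is 6 h with an expected range of 3 h to 11 h in this read-out.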

Compound 3, half-life: 4 h
For compound 3 the middle estimate is 1.5-fold (0.18 log units) above the measured one; the range from low to high includes it.
By their numbers in this assay, from the lowest: compounds 3, 1 and 2 (each within the scatter of the next).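

The position on an aromatic carbon, meta to a large group, now has a measured step: in this assay trifluoromethyl in place of chloro gives a 1.5-fold lower number from compound 1 to compound 3 (0.18 log units; within the scatter) for the change from 3-chlorophenyl to 3-(trifluoromethyl)phenyl. A group with more heavy atoms, and no hydrogen-bond donors or acceptors, can therefore stand at this position without the half-life separating from that of the chloro compound beyond the scatter. Nothing in hand accounts for the half-life of either compound.

Open, going by these compounds, is whether a methoxy group, an amine or a carboxylic acid at this position would stay level with chloro and trifluoromethyl, or whether plain hydrogen would. Also open, on these data alone, is whether the same change would read alike on the core of compound 2, which carries neither group.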